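Swapping Thiophene for Nitrophenyl in a Cytotoxicity Series

The source may report more compounds than this note shows. Statements on the series, on what has been measured and on what is new or still open speak of the compounds shown alone.

Measured compounds:
compound 1 `Cc1cc(-c2cccs2)cn2c(CSCCc3ccccc3)cnc12`: 20 ug/mL
compound 2 `c1ccc(CCSCc2cnc3ccc(-c4ccccc4)cn23)cc1`: 4 ug/mL

Of the compounds shown here, two have been tested in an ADME assay on HEL cells (Homo sapiens) for cytotoxicity, with a stated time of 3 days; on this read-out lower numbers stand for higher toxicity in this test and higher numbers for lower toxicity in this test. Compound 1 gives 20 ug/mL in this assay, the higher of the two numbers, and compound 2 gives 4 ug/mL, a lower number that lies beyond the usual scatter. Among the compounds with values here, compound 2 differs from compound 1 in more than one place, so no single step between them can be read off.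

Compound 3 `Cc1cc(-c2cccc([N+](=O)[O-])c2)cn2c(CSCCc3ccccc3)cnc12` is not yet measured. It keeps the shared core of compound 1 and changes one group: 3-nitrophenyl in place of thiophen-2-yl on an aromatic carbon

Within the data shown here, with no comparable step among the measured compounds, the expected step of a 1.7-fold lower number from compound 1 to compound 3 (0.22 log units; within the scatter) is small and slightly toward a lower number, close to the edge of the scatter. Compound 3 is therefore estimated at 12 ug/mL in this assay, within a range from 4 ug/mL to 50 ug/mL.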

Compound 3, minimum cytotoxic concentration: >= 100 ug/mL
Compound 3 was reported as a limit (the forecaster's own chance of this, stated with the estimate: 10%); at least 8.3-fold (0.92 log units) between middle value and limit.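

In this assay, compound 3 gives >= 100 ug/mL, which is a limit of the assay and not a number. Within the data shown here, putting 3-nitrophenyl in place of thiophen-2-yl on this aromatic carbon gives an at least 5.0-fold higher number from compound 1 to compound 3 (0.69 log units; beyond the scatter), the first single-change comparison here, and it shows that the group at this position can shift the read-out toward lower toxicity in this test. The full size of the step cannot be given because it rests on a limit: the limit of >= 100 ug/mL in this assay, at which 1 of the 3 values shown sits.

As far as these compounds go, it remains open whether the nitro group or the carbon-only six-membered ring matters more; a phenyl ring carrying an amine or a carboxylic acid in place of the nitro group, on the core of compound 1, would help separate the two. From the compounds shown here alone, whether the same swap acts alike without the methyl group is also open.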